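This account rests on a few compounds, and the source may have more. Where it says the series, first, only, none or still open, it means among the compounds named here.

Compounds measured in a functional assay on HCT-116 cells (Homo sapiens) for positive allosteric modulation, read by MTT assay, with stated times of 24 h and 48 h, tested at 2.5 uM; a lower number here means less inhibition of growth, a higher number more inhibition of growth at the concentration tested:
- compound 1, `N#Cc1ccc(-c2cnc3[nH]cc(-c4nnc(-c5ccc(F)cc5)o4)c(=O)c3c2)cc1`: 25.6%
- compound 2, `N#Cc1ccc(-c2cnc3[nH]cc(-c4nnc(-c5ccc(Cl)cc5)o4)c(=O)c3c2)cc1`: 35.4%

Compound 1 and compound 2 share one core and differ only in the halogen on the outer phenyl ring. In this assay compound 1 gives 25.6%, the lowest of the two numbers, and compound 2 gives 35.4%. The step of a number 9.8 percentage points higher from compound 1 to compound 2 (within the scatter) is within the scatter, so the two compounds cannot be told apart on these data.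

Compound 3, `O=c1c(-c2nnc(-c3ccc(F)cc3)o2)c[nH]c2ncc(-c3ccncc3)cc12`, keeps the fluoro phenyl of compound 1 and alters the other end of the core: pyridin-4-yl in place of 4-cyanophenyl on an aromatic carbon. Going by the values given here, no measured pair shows this exchange; the only measured step, the halogen swap from compound 1 to compound 2, concerns a different part of the molecule and was itself within the scatter. It therefore gives no reason to expect a shift beyond the scatter here, in either direction. The expected step of a number 0.6 percentage points lower from compound 1 to compound 3 (within the scatter) is accordingly small. For compound 3 the estimate in this assay is 25%, with a range from 10% to 40%.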

Compound 3, percent growth inhibition at one concentration: 19.6%
Beside the measured number, compound 3's estimate is 5.4 percentage points above it; the range from low to high includes it.
By their numbers in this assay, from the lowest: compounds 3, 1 and 2 (each within the scatter of the next, the first and the last beyond it).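

In this assay, the exchange of 4-cyanophenyl for pyridin-4-yl is the only change shown at this position on the shared core, and it gives a number 6 percentage points lower from compound 1 to compound 3 (within the scatter) for the two compounds. The earlier halogen swap concerned the outer phenyl ring, so this step is the first reading of how much this other end of the molecule matters: losing the nitrile and its triple bond, and placing a nitrogen in the aromatic ring, does not shift growth inhibition beyond the scatter at this one concentration, and the nitrile is therefore not shown to be needed here. No measurement on these compounds bears on the reason for this result.

Still open, as far as these compounds go, is whether a different kind of group at this position, such as an amine, a carboxylic acid or a morpholine ring, would separate from compound 1 by more than the scatter in this assay. From the compounds shown here alone, it is also open whether pyridin-4-yl would give a similar reading when paired with the chloro phenyl of compound 2.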